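Fluorobenzyl to propargyl on a weakly active core

The compounds below may be only part of what the source reports. "The series", "measured", "known", "first", "only" and "open" are said of these compounds alone.

Going by the values given here, in an ADME assay on GES1 cells (Homo sapiens) for inhibition, read by MTT assay, with a stated time of 72 h (on this read-out lower numbers stand for stronger inhibition and higher numbers for weaker inhibition), compound 2 `Cc1cc(Nc2cc(-c3ccccc3)[nH]n2)n2nc(SCc3ccc(F)cc3)nc2n1` gives 35500 nM, the only plain number among the three measured compounds. Compound 1 `Cc1cc(Nc2cc(-c3ccccc3)[nH]n2)n2nc(SCc3cccc(Br)c3)nc2n1` reaches only > 50000 nM, which is a limit of the assay and not a number. Compound 3 `Cc1ccc(Cn2ccc(Nc3cc(C)nc4nc(SCc5ccc(Br)cc5)nn34)n2)cc1` likewise stops at the limit > 50000 nM. Among the compounds with values here, the one step that can be weighed, an at least 1.4-fold lower number from compound 1 to compound 2 (0.14 log units; that floor lies within the scatter), sits within the scatter, and the limit of > 50000 nM in this assay, at which 2 of the 3 values shown sit, marks where most of the values rest. Compound 4 `C#CCSc1nc2nc(C)cc(Nc3cc(-c4ccccc4)[nH]n3)n2n1` differs from compound 2 by ethynyl in place of 4-fluorophenyl on a saturated chain carbon bound to a sulfur. No measured step touches an ethynyl group, so the measured steps offer only a sense of how little the numbers move among these compounds. Compound 4 is therefore expected to stay weak, with an estimated step of a 1.3-fold higher number from compound 2 to compound 4 (0.10 log units; within the scatter) that does not leave the scatter, and a real chance that this assay again reports only a limit. The estimate for compound 4 is 45000 nM, with a range from 15000 nM to 120000 nM.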

Compound 4, half-maximal inhibitory concentration: 45700 nM
Estimate against measurement, compound 4: 1.0-fold (0.01 log units) below, and the stated range covers the measured number.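

Going by these compounds alone, until now the only step at this position, on a saturated chain carbon bound to a sulfur, exchanged one substituted phenyl ring for another; here the aromatic ring goes altogether, and in this assay the change gives a 1.3-fold higher number from compound 2 to compound 4 (0.11 log units; within the scatter). The comparison with the 3-bromophenyl compound reads an at least 1.0-fold lower number from compound 1 to compound 4 (0.03 log units; that floor lies within the scatter), which is only a floor, since the value for compound 1 is a limit of the assay and not a number. These readings all lie close to the top of what the assay reports: the limit of > 50000 nM in this assay, at which 2 of the 4 values shown sit.

The compounds shown leave open whether any group at this position can move the number beyond the scatter. A primary amine, a carboxylic acid or a longer alkyl chain in place of ethynyl would test this.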